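Nitro on the fused ring in a quinolone series

A few compounds are considered here, and "the series" means these few. Any claim that something is new, unique, unknown or untested is made for them only; others in the source may bear on it.

The series shares a core carrying a basic amine-bearing ring and a fused bicyclic heteroaryl substituent. Compound 1 `CCn1cc(-c2nc3ccccc3s2)c(=O)c2cc(F)c(N3CCNCC3)cc21` is the parent; compound 3 `CCn1cc(-c2nc3ccc([N+](=O)[O-])cc3s2)c(=O)c2cc(F)c(N3CCNCC3)cc21` carries the change (nitro in place of hydrogen on an aromatic carbon). Compound 2 `CCn1cc(-c2nc3ccccc3s2)c(=O)c2cc(F)c(N3CCNC(C)C3)c(F)c21` has a differently substituted core; the difference between the two cores is not broken down here. Compound 4 `CCn1cc(-c2nc3ccc([N+](=O)[O-])cc3s2)c(=O)c2cc(F)c(N3CCNC(C)C3)c(F)c21` is the analogue of compound 2 with the change (nitro in place of hydrogen on an aromatic carbon).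

In a functional assay on KB cells (Homo sapiens) for cytotoxicity, read by MTT assay, with a stated time of 48 h (on this read-out lower numbers stand for stronger inhibition and higher numbers for weaker inhibition), compound 1 gives 28700 nM and compound 3 gives 700 nM, a step of a 41-fold lower number from compound 1 to compound 3 (1.61 log units; beyond the scatter). Compound 2 gives 24300 nM in this assay, within the scatter of compound 1. Both places of change are described in the same words, so the move from compound 2 to compound 4 is the same change already seen once.

Going by the values given here, for compound 4 a step of a 35-fold lower number from compound 2 to compound 4 (1.54 log units; beyond the scatter) in this assay is expected, because the single measured instance gave a 41-fold lower number from compound 1 to compound 3 (1.61 log units; beyond the scatter). Compound 4 is therefore estimated at 700 nM, with a range from 250 nM to 2500 nM.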

Compound 4, half-maximal inhibitory concentration: 4700 nM
Compound 4: the middle estimate sits 6.7-fold (0.83 log units) below what was measured; the whole stated range lies below it.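

On the differently substituted core, the nitro in place of hydrogen again lowers the number in this assay, with a 5.2-fold lower number from compound 2 to compound 4 (0.71 log units; beyond the scatter), so the direction of the step carries over between the two cores. Its size does not carry over, and a step measured on one core cannot be applied unchanged to the other: the same change on two cores in this assay, a 41-fold lower number (1.61 log units; beyond the scatter) from compound 1 to compound 3 and a 5.2-fold lower number (0.71 log units; beyond the scatter) from compound 2 to compound 4, 7.9-fold (0.90 log units) apart, beyond the scatter of two such steps

The two cores differ in more than one place, and these four compounds do not show which difference goes with the smaller step, nor how the step would run on any further core.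

Still open, as far as these compounds go, is whether another group in the same place on the fused ring system, such as a carboxylic acid or a nitrile, would give a step like that of nitro. Also open, from the compounds shown here alone, is how the added methyl and the added fluorine, each taken alone, would bear on the size of the step.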